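Dropping the ethyl from the piperazine of compound 2

A few compounds are considered here, and "the series" means these few. Any claim that something is new, unique, unknown or untested is made for them only; others in the source may bear on it.

The series is followed in a functional assay on CCRF-CEM cells for antagonist activity at C-X-C chemokine receptor type 4 (Homo sapiens), read by calcium flux, with stated times of 25 min and 90 s; on this read-out higher numbers stand for weaker inhibition and lower numbers for stronger inhibition. Compound 1, with the structure `FC1(F)CCC(CN(C[C@H]2Cc3c(cccc3N3CCNCC3)CN2)[C@H]2CCCc3cccnc32)CC1`, gives 498 nM in this assay. Compound 2, with the structure `CCN1CCN(c2cccc3c2C[C@H](CN(C)[C@H]2CCCc4cccnc42)NC3)CC1`, gives 13.8 nM in this assay, the lowest of the two numbers shown, and its nearest neighbour is compound 1, whose number is higher by a margin beyond the scatter. Compound 1 and compound 2 differ from each other in more than one place, so these two values show only where each stands, not what any single change does.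

Compound 3, with the structure `CN(C[C@H]1Cc2c(cccc2N2CCNCC2)CN1)[C@H]1CCCc2cccnc21`, is the unmeasured member. It differs from compound 2 in one place: hydrogen in place of ethyl on an amine nitrogen in a ring. Among the compounds with values here, no measured pair isolates this change, so there is nothing in the data to fix its size or direction. The step from compound 2 to compound 3 is expected to be small, most likely within the scatter, a 1.4-fold higher number from compound 2 to compound 3 (0.16 log units; within the scatter). On that basis compound 3 is expected to give about 20 nM in this assay, within a range from 6 nM to 70 nM.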

Compound 3, half-maximal inhibitory concentration: 6.08 nM
For compound 3 the middle estimate is 3.3-fold (0.52 log units) above the measured one; the range from low to high includes it.
By their numbers in this assay, from the lowest: compound 3; then compound 2; then compound 1.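

Taking the ethyl off the ring amine nitrogen gives a 2.3-fold lower number from compound 2 to compound 3 (0.36 log units; beyond the scatter) in this assay, so on this position the 4-ethylpiperazin-1-yl group can give way to the unsubstituted piperazin-1-yl group with a modest gain that lies beyond the scatter. Compound 3 also links compound 1 to the series through a single change with the piperazin-1-yl group held constant: hydrogen in place of 4,4-difluorocyclohexyl on a saturated chain carbon bound to an amine nitrogen gives an 82-fold lower number from compound 1 to compound 3 (1.91 log units; beyond the scatter), a large step that far exceeds the one at the ring nitrogen. No measurement presented here accounts for either step.

Ethyl and hydrogen are the only two substituents compared on this ring nitrogen, so it remains open whether a 2-hydroxyethyl group, an acetyl group or a longer alkyl chain there would continue the same trend. Also open, going by these compounds, is whether the ethyl-to-hydrogen step keeps its direction and size when 4,4-difluorocyclohexyl is present on the chain carbon, and how a smaller ring such as cyclopropyl would fare at that place.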